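The source may report more compounds than this note shows. Statements on the series, on what has been measured and on what is new or still open speak of the compounds shown alone.

Working notes on the series. Three compounds share one core and differ only in the aryl group that sits on it: compound 1 `CCC1=C(O)c2c(oc(-c3ccc(C)cc3)cc2=O)C(CC)(CC)C1=O`, compound 2 `CCC1=C(O)c2c(oc(-c3ccc(OC(F)(F)F)cc3)cc2=O)C(CC)(CC)C1=O` and compound 3 `CCC1=C(O)c2c(oc(-c3ccc(F)cc3)cc2=O)C(CC)(CC)C1=O`. In a functional assay on KB cells (Homo sapiens) for antiproliferative activity, read by sulforhodamine B assay, with a stated time of 3 days (a lower number here means that less compound is needed, a higher number that more compound is needed for the effect), compound 1 gives 39.2 uM, compound 2 gives 36.5 uM and compound 3 gives 33 uM. The three steps among them are all small: a 1.1-fold lower number from compound 1 to compound 2 (0.03 log units; within the scatter), a 1.2-fold lower number from compound 1 to compound 3 (0.07 log units; within the scatter) and a 1.1-fold lower number from compound 2 to compound 3 (0.04 log units; within the scatter). Compound 3 therefore stands in a cluster with compound 1 and compound 2 that the scatter does not separate.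

Compound 4 `CCC1=C(O)c2c(oc(-c3ccc(C)cc3C)cc2=O)C(CC)(CC)C1=O` is not yet measured. Relative to compound 3 the change is 2,4-dimethylphenyl in place of 4-fluorophenyl on an aromatic carbon. Within the data shown here, the steps that bear on it are those that exchange the group on the same aryl ring, that is a 1.2-fold lower number from compound 1 to compound 3 (0.07 log units; within the scatter), a 1.1-fold lower number from compound 1 to compound 2 (0.03 log units; within the scatter) and a 1.1-fold lower number from compound 2 to compound 3 (0.04 log units; within the scatter), none of which moved this assay beyond the scatter. Among the measured compounds shown here, the second methyl of the 2,4-dimethylphenyl has no counterpart among the measured compounds, so its effect is not known. For compound 4 the expected step is a 1.1-fold higher number from compound 3 to compound 4 (0.04 log units; within the scatter), that is, no change beyond the scatter. The estimate for compound 4 is 36 uM, in the range 18 uM to 72 uM.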

Compound 4, concentration for half-maximal effect: 41.2 uM
Compound 4: middle estimate off by 1.1-fold (0.06 log units), on the low side; measured number inside the range.
By their numbers in this assay, from the lowest: compounds 3, 2, 1 and 4 (each within the scatter of the next).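

The added methyl of the 2,4-dimethylphenyl gives the series its first aryl ring with a second substituent, and in this assay this methyl in place of hydrogen gives a 1.1-fold higher number from compound 1 to compound 4 (0.02 log units; within the scatter), so the second substituent does not separate compound 4 from compound 1. The larger exchange, 2,4-dimethylphenyl in place of 4-fluorophenyl, gives a 1.2-fold higher number from compound 3 to compound 4 (0.10 log units; within the scatter), which also leaves the number within the scatter, so all four compounds now stand in one cluster and no change on this aryl ring has yet produced a step beyond it. Nothing available here bears on why these changes leave the number in place.

On these data alone, it remains open whether a group of another kind on this aryl ring, such as an amine, a carboxylic acid or a longer alkyl chain, would move the number beyond the scatter, or whether the ring can be replaced altogether. The shared core stays constant across all four compounds, so the compounds shown say nothing about how much of the antiproliferative effect depends on it rather than on the aryl group.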